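A few compounds are considered here, and "the series" means these few. Any claim that something is new, unique, unknown or untested is made for them only; others in the source may bear on it.

Compound 1 `CCN1CCN(C[C@H]2CN(c3ccc(-n4cc(-c5ccccn5)cn4)c(F)c3)C(=O)O2)CC1`: 99 ug/mL
Compound 2 `O=C1CCC(=O)N1C[C@H]1CN(c2ccc(-n3cc(-c4ccccn4)cn3)c(F)c2)C(=O)O1`: > 400 ug/mL
Compound 3 `CS(=O)(=O)NC[C@H]1CN(c2ccc(-n3cc(-c4ccccn4)cn3)c(F)c2)C(=O)O1`: 314 ug/mL

These three compounds share one core and differ only in the group on a saturated chain carbon bound to a saturated ring carbon. In an ADME assay on HEK293-A cells (Homo sapiens) for cytotoxicity, read by MTT assay, with a stated time of 48 h (a higher number here means a weaker inhibitor, a lower number a stronger inhibitor), compound 1 gives the lowest of the three numbers. For compound 2 this assay reports only a limit, > 400 ug/mL, and no number, as noted in the limit of > 400 ug/mL in this assay, at which 1 of the 3 values shown sits. The step of an at least 4.0-fold higher number from compound 1 to compound 2 (0.60 log units; beyond the scatter) and the step of a 3.2-fold higher number from compound 1 to compound 3 (0.50 log units; beyond the scatter) both run upward, while the step of an at least 1.2-fold lower number from compound 2 to compound 3 (0.10 log units; that floor lies within the scatter) stays within the scatter at its floor.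

Compound 4 `O=C1O[C@@H](CNC(=O)C(F)(F)F)CN1c1ccc(-n2cc(-c3ccccn3)cn2)c(F)c1` differs from compound 2 by ((trifluoromethyl)carbonyl)amino in place of 2,5-dioxopyrrolidin-1-yl on a saturated chain carbon bound to a saturated ring carbon. The step that bears on it most is an at least 1.2-fold lower number from compound 2 to compound 3 (0.10 log units; that floor lies within the scatter), where another group of similar size, methanesulfonamido, replaced 2,5-dioxopyrrolidin-1-yl in the same place with no change beyond the scatter. Compound 4 is therefore expected to land in this assay near compound 2, at 340 ug/mL, between 180 ug/mL and 600 ug/mL. That expectation means a step of an at least 1.1-fold lower number from compound 2 to compound 4 (0.07 log units; that floor lies within the scatter), which is estimated to be no change beyond the scatter, with a fair chance that only a limit is reported again.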

Compound 4, half-maximal inhibitory concentration: > 400 ug/mL
Compound 4: no number, only a limit; the forecaster's own chance of this, stated with the estimate: 45%; middle value at least 1.1-fold (0.07 log units) from the limit.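

In this assay, compound 4 gives only a limit, so a group with no ring and one hydrogen-bond donor at this place on the saturated chain carbon also leaves the assay without a number: the limit of > 400 ug/mL in this assay, at which 2 of the 4 values shown sit. The step between the two limits cannot be read. The change of methylsulfonyl to (trifluoromethyl)carbonyl on the amine nitrogen gives an at least 1.2-fold higher number from compound 3 to compound 4 (0.10 log units; that floor lies within the scatter) and so shows no change beyond the scatter at its floor, whereas replacing 4-ethylpiperazin-1-yl gives an at least 4.0-fold higher number from compound 1 to compound 4 (0.60 log units; beyond the scatter) and leaves compound 1 apart from all three other compounds.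

As far as these compounds go, the order of compound 2 and compound 4 remains unknown. From the compounds shown here alone, it also remains open whether a primary amine, a carboxylic acid or a longer chain at this place would stay near compound 1 or near the other three compounds.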